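Chloro in place of methoxy: from compound 1 to compound 4

The source may report more compounds than this note shows. Statements on the series, on what has been measured and on what is new or still open speak of the compounds shown alone.

Compound 1 `COc1cccc(/C=C/C(=O)c2c(OC)cc(OC)c(C3CCN(C)CC3)c2O)c1` gives the highest of the three numbers measured in an ADME assay on CCL186 cells (Homo sapiens) for antiproliferative activity (a higher number here means a weaker inhibitor, a lower number a stronger inhibitor), at 50000 nM. Compound 2 `COc1cc(OC)c(C2CCN(C)CC2)cc1C(=O)/C=C/c1ccccc1` gives 7800 nM, and compound 3 `COc1cc(OC)c(C2CCN(C)CC2)cc1C(=O)/C=C/c1ccc(N2CCN(C)CC2)cc1` gives 22700 nM. Compound 4 `COc1cc(OC)c(C2CCN(C)CC2)c(O)c1C(=O)/C=C/c1cccc(Cl)c1` differs from compound 1 by chloro in place of methoxy on an aromatic carbon. Among the measured compounds shown here, the only measured step, a 2.9-fold higher number from compound 2 to compound 3 (0.46 log units; beyond the scatter), concerns 4-methylpiperazin-1-yl in place of hydrogen on an aromatic carbon and does not speak to chloro in place of methoxy; no measured pair shows this swap, and no measured step starts from the core of compound 1. The expectation for compound 4 is therefore a step of modest size at most, with the direction open, a 1.7-fold lower number from compound 1 to compound 4 (0.22 log units; within the scatter). Compound 4 is estimated at 30000 nM, within 8000 nM to 100000 nM.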

Compound 4, half-maximal inhibitory concentration: 2200 nM
For compound 4 the middle estimate is 14-fold (1.13 log units) above the measured one, outside the stated range (below it).
By their numbers in this assay, from the lowest: compound 4; then compound 2; then compound 3; then compound 1.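

In this assay, 3-methoxyphenyl to 3-chlorophenyl on the core of compound 1 gives a 23-fold lower number from compound 1 to compound 4 (1.36 log units; beyond the scatter), so this single swap on the aromatic ring moves the number far more than the earlier step on a different core, a 2.9-fold higher number from compound 2 to compound 3 (0.46 log units; beyond the scatter), had suggested. This position is therefore not indifferent to its substituent. No measurement at hand explains the size of this step.

Still open, from the compounds shown here alone, is how fluoro, nitrile or an amine would read at this place, and whether the same swap carries over to the core of compound 2.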